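Ether variation at the saturated ring carbon of the core

The compounds below may be only part of what the source reports. "The series", "measured", "known", "first", "only" and "open" are said of these compounds alone.

Compound 1 `Cc1nn(-c2ncnc3nc[nH]c23)c2c1C(C(=O)Nc1ccccc1)CC(=O)N2` carries a phenylcarbamoyl group on a saturated ring carbon of the shared core; in a functional assay on HEK293 cells for agonist activity at G-protein coupled receptor 39 (Homo sapiens), read by scintillation proximity assay and inositol phosphate accumulation, with a stated time of 75 min, in the presence of a further agent that is not named here (a higher number here means that more compound is needed for the effect, a lower number that less compound is needed), compound 1 gives 10 nM. Compound 2 `Cc1nn(-c2ncnc3nc[nH]c23)c2c1C(OCc1ccccc1F)CC(=O)N2` replaces that group with a (2-fluorobenzyl)oxy ether, and in this assay compound 2 gives 4 nM. Compound 3 `Cc1nn(-c2ncnc3nc[nH]c23)c2c1C(OCc1ccc(C#N)cc1)CC(=O)N2` carries the (4-cyanobenzyl)oxy ether instead, and in this assay compound 3 gives 4 nM. The steps of a 2.5-fold lower number from compound 1 to compound 2 (0.40 log units; beyond the scatter) and a 2.5-fold lower number from compound 1 to compound 3 (0.40 log units; beyond the scatter) both favour the ethers over the amide, while no change at the digits printed from compound 2 to compound 3 (within the scatter) shows the two aryl groups on the ether side as equivalent. Compound 3 therefore stands level with compound 2, the two together holding the lowest numbers of the three, with compound 1 furthest from it.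

Compound 4 `Cc1nn(-c2ncnc3nc[nH]c23)c2c1C(OCCn1cccn1)CC(=O)N2` keeps the ether and changes its far end: (1H-pyrazol-1-yl)methyl in place of 4-cyanophenyl on a saturated chain carbon bound to an oxygen on a saturated carbon. For the measured compounds named here, no measured step covers exchange of the aryl ring for the 2-(1H-pyrazol-1-yl)ethyl chain; the only step on the ether side, no change at the digits printed from compound 2 to compound 3 (within the scatter), stayed within the scatter. On that basis the step of a 1.8-fold higher number from compound 3 to compound 4 (0.24 log units; within the scatter) is expected to remain modest, with a small loss more likely than a gain. Compound 4 is estimated at 7 nM in this assay, with a range from 2.5 nM to 25 nM.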

Compound 4, half-maximal effective concentration: 16 nM
Estimate against measurement, compound 4: 2.3-fold (0.36 log units) below; the measured number falls inside the stated range.
By their numbers in this assay, from the lowest: compounds 2 and 3 (each within the scatter of the next); then compounds 1 and 4 (each within the scatter of the next).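

For the compounds shown here, at the far end of the ether on the saturated ring carbon, the aryl groups are not interchangeable with every replacement: in this assay, exchanging them for the 1H-pyrazol-1-yl end gives the first steps on the ether side that lie beyond the scatter (a 4.0-fold higher number from compound 3 to compound 4 (0.60 log units; beyond the scatter); a 4.0-fold higher number from compound 2 to compound 4 (0.60 log units; beyond the scatter)). The ether link alone therefore does not secure the lower numbers of compound 2 and compound 3, and the 2-(1H-pyrazol-1-yl)ethoxy group stays level with the phenylcarbamoyl group (a 1.6-fold higher number from compound 1 to compound 4 (0.20 log units; within the scatter)). No supporting measurement is available to explain why the far end of the ether matters at this position.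

The change swaps the ring and lengthens the link to it at once, so the compounds shown leave open which of the two accounts for the higher number; a 2-phenylethoxy group on the same carbon would separate them. Also open, on these data alone, is how the position responds to a pyridin-3-ylmethoxy ether, or to an amine or a carboxylic acid at the end of a longer chain.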